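Diaryl urea series: trifluoromethyl to chloro swap

The compounds below may be only part of what the source reports. "The series", "measured", "known", "first", "only" and "open" are said of these compounds alone.

Compound 1 `COc1cc2cc(Oc3ccc(NC(=O)Nc4cccc(C(F)(F)F)c4)cc3)c(C)nc2cc1OC` and compound 2 `COc1cc2cc(Oc3ccc(NC(=O)Nc4ccc(Cl)c(C(F)(F)F)c4)cc3)c(C)nc2cc1OC` share one core and differ by a single chloro on an aromatic carbon. In a functional assay on SK-MEL-5 cells (Homo sapiens) for inhibition, read by sulforhodamine B assay, with a stated time of 48 h (a lower number here means a stronger inhibitor of growth, a higher number a weaker inhibitor of growth), compound 1 gives 1080 nM, and compound 2 gives 793 nM; the step of a 1.4-fold lower number from compound 1 to compound 2 (0.13 log units; within the scatter) leaves the two values within the scatter of each other, so neither stands apart. Compound 3 `COc1cc2cc(Oc3ccc(NC(=O)Nc4ccc(Cl)c(Cl)c4)cc3)c(C)nc2cc1OC` differs from compound 2 by chloro in place of trifluoromethyl on an aromatic carbon. For the measured compounds named here, the only measured step was a different change and small; no measured pair exchanges trifluoromethyl for chloro. The expected step of a 1.5-fold higher number from compound 2 to compound 3 (0.18 log units; within the scatter) is therefore none beyond the scatter. Compound 3 is estimated at 1200 nM, within 500 nM to 3000 nM.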

Compound 3, concentration for 50% growth inhibition: 2580 nM
Beside the measured number, compound 3's estimate is 2.2-fold (0.33 log units) below it; low and high end bracket the measured number.
By their numbers in this assay, from the lowest: compounds 2 and 1 (each within the scatter of the next); then compound 3.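

Exchanging trifluoromethyl for chloro at this position, ortho to a chloro group, moves the number beyond the scatter in this assay (a 3.3-fold higher number from compound 2 to compound 3 (0.51 log units; beyond the scatter)), whereas the earlier chloro step stayed within it. The 3,4-dichlorophenyl group also gives a weaker inhibitor of growth than 3-(trifluoromethyl)phenyl (a 2.4-fold higher number from compound 1 to compound 3 (0.38 log units; beyond the scatter)), so trifluoromethyl at this position goes with the lower numbers in these three compounds. Nothing at hand accounts for the size of either step.

Open, on these data alone, is how a methoxy group, a nitrile or an amine at this position would compare with trifluoromethyl and chloro.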